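The source may hold more compounds than are shown below. What is called first, only, known or untested is meant among the compounds shown, and "the series" means these compounds.

Compound 1 `CN(C)CCCNc1nc(-c2ccc(NC(=O)Nc3ccc(F)cc3)cc2)nc2c(Cl)c(Cl)sc12`: 430 nM
Compound 2 `CN(C)CCCNc1nc(-c2ccc(NC(=O)Nc3ccccc3Cl)cc2)nc2c(Cl)c(Cl)sc12`: 820 nM

In a functional assay on HT-29 cells (Homo sapiens) for cytotoxicity, read by MTT assay, with a stated time of 72 h (on this read-out lower numbers stand for stronger inhibition and higher numbers for weaker inhibition), compound 1 gives the lowest of the two numbers, with compound 2 nearest to it at a 1.9-fold higher number from compound 1 to compound 2 (0.28 log units; within the scatter). Compound 3 `CCN(CC)CCNc1nc(-c2ccc(NC(=O)Nc3ccc(F)cc3)cc2)nc2c(Cl)c(Cl)sc12` differs from compound 1 by diethylamino in place of (dimethylamino)methyl on a saturated chain carbon, two bonds along the chain from a nitrogen on an aromatic ring. Among the compounds with values here, the single measured step, a 1.9-fold higher number from compound 1 to compound 2 (0.28 log units; within the scatter), changes the aryl group on the urea and not the amine chain, so it bears only loosely on this change; no step along the chain itself is known. Compound 3 is therefore expected to show no step beyond the scatter, an estimate of 500 nM with a range of 200 nM to 1300 nM, a step of a 1.2-fold higher number from compound 1 to compound 3 (0.07 log units; within the scatter).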

Compound 3, half-maximal inhibitory concentration: 650 nM
Compound 3: the middle estimate sits 1.3-fold (0.11 log units) below what was measured, within the range that was stated.
By their numbers in this assay, from the lowest: compounds 1, 3 and 2 (each within the scatter of the next).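

Along the amine chain, the only step in this assay is a 1.5-fold higher number from compound 1 to compound 3 (0.18 log units; within the scatter), so (2-(diethylamino)ethyl)amino in place of (3-(dimethylamino)propyl)amino leaves the number within the scatter. This position therefore accepts this one change, which alters both the chain and the groups on its terminal nitrogen, while the 4-fluorophenyl urea stays in place. No measurement at hand explains this result. On these data alone, the effects of chain length and of the terminal groups remain unseparated, and a longer chain, a primary amine or a morpholine is still open. Also open, as far as these compounds go, is whether the change would give a similar step with the 2-chlorophenyl urea of compound 2.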